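The compounds below may be only part of what the source reports. "The series", "measured", "known", "first", "only" and "open" are said of these compounds alone.

In a functional assay on HL-60 cells (Homo sapiens) for inhibition (on this read-out lower numbers stand for stronger inhibition and higher numbers for weaker inhibition), compound 1 `COc1cc(/C=C/c2occc2C)cc(OC)c1OC` gives 3650 nM and compound 3 `COc1cc(/C=C\c2cn(C(C)=O)c3ccccc23)cc(OC)c1OC` gives 2850 nM. Compound 2 `COc1cc(/C=C/c2cn(C(C)=O)c3ccccc23)cc(OC)c1OC` gives only a limit, > 5000 nM, so it has no exact place among these numbers.

Going by the values given here, the one measured step from compound 2 is an at least 1.7-fold lower number from compound 2 to compound 3 (0.24 log units; that floor lies within the scatter). It comes with the fact that compounds 2 and 3 differ only in the configuration as drawn, so it says nothing about the group on the nitrogen.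

Compound 4 `COc1cc(/C=C/c2c[nH]c3ccccc23)cc(OC)c1OC` keeps the E double bond of compound 2 and changes in one place: hydrogen in place of acetyl on an aromatic nitrogen. Among the compounds with values here, no measured step shows this exchange, so its size must be judged loosely. The nearest guide is compound 3 at 2850 nM. This suggests a value for compound 4 not far from the limit of compound 2, and a small move toward a lower number is expected, possibly no more than the scatter. The expected step is an at least 1.4-fold lower number from compound 2 to compound 4 (0.15 log units; that floor lies within the scatter), and its starting point is only a limit. Compound 4 is estimated at 3500 nM, with an expected range from 1000 nM to 10000 nM.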

Compound 4, half-maximal inhibitory concentration: 3230 nM
The estimate for compound 4 lay 1.1-fold (0.03 log units) above the measured number; the range from low to high includes it.
By their numbers in this assay, from the lowest: compounds 3, 4 and 1 (each within the scatter of the next). At a limit, above all of these: compound 2.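

In this assay, going by these compounds alone, the exchange of acetyl for hydrogen on the aromatic nitrogen gives the first measured step at this position, and it replaces a limit with an exact number: an at least 1.5-fold lower number from compound 2 to compound 4 (0.18 log units; that floor lies within the scatter). From the compounds shown here alone, the value of compound 2 is a limit, so this step has only a floor and its full size remains unknown: the limit of > 5000 nM in this assay, at which 1 of the 4 values shown sits. The earlier step could not speak to this exchange, as the group on the nitrogen stayed the same: the fact that compounds 2 and 3 differ only in the configuration as drawn.

The compounds shown leave open how a methyl or a benzoyl group on this nitrogen would compare with hydrogen and acetyl. They also leave open what the Z double bond would give with hydrogen on the aromatic nitrogen.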